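Dimethylamino on the amide ring: pyridyl analogue

The source may hold more compounds than are shown below. What is called first, only, known or untested is meant among the compounds shown, and "the series" means these compounds.

In an assay on isolated protein for displacement of a labelled ligand from secreted frizzled-related protein 1 (Homo sapiens), read by fluorescence polarization, with a stated time of 30 min (on this read-out higher numbers stand for weaker inhibition and lower numbers for stronger inhibition), compound 1 `O=C(c1ccccc1)N1CCC(NS(=O)(=O)c2cc(S(=O)(=O)c3ccccc3)ccc2C(F)(F)F)CC1` gives 70 nM, compound 2 `CN(C)c1ccc(C(=O)N2CCC(NS(=O)(=O)c3cc(S(=O)(=O)c4ccccc4)ccc3C(F)(F)F)CC2)cc1` gives 300 nM, and compound 3 `O=C(c1ccccn1)N1CCC(NS(=O)(=O)c2cc(S(=O)(=O)c3ccccc3)ccc2C(F)(F)F)CC1` gives 60 nM. Compound 3 has the lowest number of the three, but its gap to compound 1 is within the scatter, as a 1.2-fold lower number from compound 1 to compound 3 (0.07 log units; within the scatter) shows. The change to compound 4 `CN(C)c1ccc(C(=O)N2CCC(NS(=O)(=O)c3cc(S(=O)(=O)c4ccccc4)ccc3C(F)(F)F)CC2)cn1` is 6-(dimethylamino)pyridin-3-yl in place of pyridin-2-yl on a carbonyl carbon. The bearing precedents are a 4.3-fold higher number from compound 1 to compound 2 (0.63 log units; beyond the scatter) and, in the reverse sense, a 5.0-fold lower number from compound 2 to compound 3 (0.70 log units; beyond the scatter). Adding the dimethylamino group on the aromatic ring of the amide thus raised the number modestly once, and on this basis a modestly higher number is expected in this assay. The expected step is a 4.2-fold higher number from compound 3 to compound 4 (0.62 log units; beyond the scatter). Compound 4 is expected at 250 nM, within a range of 100 nM to 700 nM.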

Compound 4, half-maximal inhibitory concentration: 40 nM
Compound 4: the middle estimate sits 6.3-fold (0.80 log units) above what was measured, outside the stated range (below it).
By their numbers in this assay, from the lowest: compounds 4, 3 and 1 (each within the scatter of the next); then compound 2.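

The 6-(dimethylamino)pyridin-3-yl group is accepted on the carbonyl carbon, with no separation from the smaller acyl groups (a 1.5-fold lower number from compound 3 to compound 4 (0.18 log units; within the scatter)) and (a 1.8-fold lower number from compound 1 to compound 4 (0.24 log units; within the scatter)). The ring carrying the dimethylamino group matters, as the pyridine stands clear of the 4-(dimethylamino)phenyl analogue (a 7.5-fold lower number from compound 2 to compound 4 (0.88 log units; beyond the scatter)), so the rise seen with compound 2 does not recur with compound 4. No measurement on hand explains this difference.

Open, on these data alone, are the unsubstituted pyridin-3-yl, which would separate the ring from the dimethylamino group, and other amines such as pyrrolidin-1-yl or morpholin-4-yl on the pyridine.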